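Adding a Second Methoxy Group to a Weakly Cytotoxic Series

A few compounds are considered here, and "the series" means these few. Any claim that something is new, unique, unknown or untested is made for them only; others in the source may bear on it.

Measured compounds:
compound 1, `COc1ccccc1CNc1ncnc2c1ncn2C1CCCCO1` — in an ADME assay on MCF7 cells (Homo sapiens) for cytotoxicity, with a stated time of 72 h (on this read-out higher numbers stand for weaker inhibition and lower numbers for stronger inhibition), compound 1 gives > 100000 nM, which is a limit of the assay and not a number.
compound 2, `COc1cccc(CNc2ncnc3c2ncn3C2CCCCO2)c1` — in this assay compound 2 gives 97000 nM.
compound 3, `COc1cccc(OC)c1CNc1ncnc2c1ncn2C1CCCCO1` — in this assay compound 3 gives > 100000 nM, again a limit of the assay and not a number.

Compound 2 is the only one of the three that returns a number. Compound 1 and compound 2 have the same atoms joined differently: 3-methoxyphenyl in place of 2-methoxyphenyl on a saturated chain carbon bound to a nitrogen on an aromatic ring. The step of an at least 1.0-fold lower number from compound 1 to compound 2 (0.01 log units; that floor lies within the scatter) tells little, since one end is a limit. From compound 1 to compound 3 the change is methoxy in place of hydrogen on an aromatic carbon; the step that the two limits leave unreadable from compound 1 to compound 3 cannot be sized because the limit of > 100000 nM in this assay, at which 2 of the 3 values shown sit, holds both ends of it.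

Compound 4, `COc1cc(CNc2ncnc3c2ncn3C2CCCCO2)cc(OC)c1`, is not yet measured in this assay. It differs from compound 2 by methoxy in place of hydrogen on an aromatic carbon. Among the compounds with values here, this is the same kind of change as the one from compound 1 to compound 3, but not the same: in compound 3 the entering group sits ortho to a large group, whereas in compound 4 it sits meta to a large group; in both it is meta to a methoxy group. Within the data shown here, the one earlier step of this kind gave no readable size. Compound 2 with 97000 nM already gives a high number, that is, weak inhibition. For compound 4 the expected step from compound 2 is a 1.0-fold higher number from compound 2 to compound 4 (0.01 log units; within the scatter), resting on that high number and on the unreadable earlier step. The estimate for compound 4 is 100000 nM, expected to fall between 50000 nM and 200000 nM, with a fair chance that the assay reports only a limit.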

Compound 4, half-maximal inhibitory concentration: > 100000 nM
Compound 4: only a limit was reported (the forecaster's own chance of this, stated with the estimate: 55%); the middle value sits exactly at the limit.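

In this assay, methoxy in place of hydrogen on an aromatic carbon gives an at least 1.0-fold higher number from compound 2 to compound 4 (0.01 log units; that floor lies within the scatter), so this step has only a floor and no measured size. The same kind of change from compound 1 to compound 3 cannot be read at all, so neither case gives a size that could be carried to the other, and the data do not show whether the change would act alike in both settings; all they show is that neither case yields a readable number. The two cases cannot be compared because compound 3 and compound 4 both end at a limit, which is not a number: the limit of > 100000 nM in this assay, at which 3 of the 4 values shown sit.

Compound 2 remains the only compound here with a number, 97000 nM, so the compounds shown leave open what would give a clearly lower number in this assay. From the compounds shown here alone, it also remains open whether an amine or a carboxylic acid in place of the methoxy group, or a longer chain in place of the single saturated carbon bound to the nitrogen, would shift the read-out from that of compound 2.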